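The source may hold more compounds than are shown below. What is called first, only, known or untested is meant among the compounds shown, and "the series" means these compounds.

Measured so far in a functional assay on P388 cells (Mus musculus); a higher number here means a weaker inhibitor, a lower number a stronger inhibitor:
compound 1 `CN(C)CC1CCC/C(=C\c2ccc(OC(=O)/C=C/c3ccccc3)cc2)C1=O` gives 4020 nM.
compound 2 `O=C1CCCC/C1=C\c1ccc(OC(=O)c2ccccc2)cc1` reaches only the assay limit, > 50000 nM.
compound 3 `Cc1ccc(C(=O)Oc2ccc(/C=C3\CCCCC3=O)cc2)cc1` likewise reaches only the assay limit, > 50000 nM.

For the measured compounds named here, compound 1 is the one member of the series with a numbered value in this assay; the other two values are limits, as the limit of > 50000 nM in this assay, at which 2 of the 3 values shown sit, records. Going by the values given here, the single step between measured compounds, a step that the two limits leave unreadable from compound 2 to compound 3, is methyl in place of hydrogen on an aromatic carbon and cannot be sized, since both ends sit at the limit. Among the compounds with values here, compounds 2 and 3 differ from compound 1 in more than one place, so no measured step connects them to it.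

Compound 4 `COc1ccc(C(=O)Oc2ccc(/C=C3\CCCC(CN(C)C)C3=O)cc2)cc1` is not yet measured. It differs from compound 1 by 4-methoxyphenyl in place of 2-phenylethenyl on a carbonyl carbon. Within the data shown here, no measured step covers this exchange, so the expectation rests on what the measured values show: compound 1, carrying 2-phenylethenyl on the carbonyl carbon, gives a number, while compounds 2 and 3, carrying aryl groups there, do not. A loss of potency is therefore expected, with a wide spread, as a 3.7-fold higher number from compound 1 to compound 4 (0.57 log units; beyond the scatter). Compound 4 is estimated at 15000 nM in this assay, within 4000 nM to 50000 nM.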

Compound 4, half-maximal inhibitory concentration: 332 nM
Estimate against measurement, compound 4: 45-fold (1.65 log units) above; the measured number lies below the stated range.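

In this assay the exchange of 2-phenylethenyl for 4-methoxyphenyl on the carbonyl carbon gives a 12-fold lower number from compound 1 to compound 4 (1.08 log units; beyond the scatter) and so shows that this position responds strongly to the group it carries. For the compounds shown here, a double bond outside aromatic rings is therefore not needed at this place for a numbered value, and the series so far holds its lowest number with an aromatic ring there. The earlier compounds shown here could not show this: compounds 2 and 3 also carry aryl groups at this place, but they stand at the assay limit and differ from compound 4 in more than one place, so those limits cannot be tied to the aryl groups alone. Nothing shown accounts for the size of the step.

Going by these compounds alone, it remains open whether the gain belongs to the methoxy group or to the aromatic ring itself, as no compound carrying the dimethylaminomethyl group has phenyl or 4-methylphenyl at this place. Also open, as far as these compounds go, is how a fluorine, a hydroxy group or a dimethylamino group in place of the methoxy group would read in this assay on the core of compound 4.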